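A few compounds are considered here, and "the series" means these few. Any claim that something is new, unique, unknown or untested is made for them only; others in the source may bear on it.

Measured compounds:
- compound 1 `COc1cc2c(Oc3ccc(NC(=O)c4cc(-c5ccccc5)nc5ccc(F)cc45)cc3F)ccnc2cc1OCCCN1CCCCC1`: 690 nM
- compound 2 `COc1cc2c(Oc3ccc(NC(=O)c4cc(-c5ccc(Cl)cc5Cl)nc5ccc(F)cc45)cc3F)ccnc2cc1OCCCN1CCCCC1`: 1040 nM

In a functional assay on U-87MG ATCC cells (Homo sapiens) for cytotoxicity, read by MTT assay, with a stated time of 72 h (on this read-out lower numbers stand for stronger inhibition and higher numbers for weaker inhibition), compound 1 gives 690 nM, the smaller of the two numbers, while compound 2 gives 1040 nM. The step of a 1.5-fold higher number from compound 1 to compound 2 (0.18 log units; within the scatter) lies within the scatter, so the two compounds cannot be told apart on these data.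

Compound 3 `COc1cc2c(Oc3ccc(NC(=O)c4cc(-c5ccccc5)nc5ccc(F)cc45)cc3F)ccnc2cc1OCCCN1CCCC1` is the next compound to be measured. It differs from compound 1 in a single place: pyrrolidin-1-yl in place of piperidin-1-yl on a saturated chain carbon, three bonds along the chain from an oxygen on an aromatic ring. The shared core and the aryl group at the far end are unchanged. Among the measured compounds shown here, the only measured step concerns that aryl group and leaves the amine ring untouched, so no measured step bears on this change. With nothing to point either way, the expectation for compound 3 in this assay is a number close to that of compound 1, with no shift beyond the scatter. Compound 3 is therefore estimated at 700 nM, in a range from 300 nM to 1600 nM. The expected step of a 1.0-fold higher number from compound 1 to compound 3 (0.01 log units; within the scatter) is essentially flat.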

Compound 3, half-maximal inhibitory concentration: 960 nM
Compound 3: the middle estimate sits 1.4-fold (0.14 log units) below what was measured; low and high end bracket the measured number.
By their numbers in this assay, from the lowest: compounds 1, 3 and 2 (each within the scatter of the next).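

Placing pyrrolidin-1-yl in place of piperidin-1-yl at the end of the 3-carbon-named 3-(piperidin-1-yl)propyl chain gives a 1.4-fold higher number from compound 1 to compound 3 (0.14 log units; within the scatter) in this assay and so adds a first reading at this position, separate from the aryl group compared earlier. Here, the five-membered and six-membered amine rings cannot be told apart, so this pair gives no sign that the choice between these two rings matters on the core of compound 1. No available evidence explains this result or links it to any property of either ring.

A morpholin-4-yl group or a dimethylamino group at the same place could still give a number beyond the scatter, and so could a longer chain carrying the piperidin-1-yl ring. The compounds shown also leave open whether pyrrolidin-1-yl would read the same alongside the 2,4-dichlorophenyl group.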